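A few compounds are considered here, and "the series" means these few. Any claim that something is new, unique, unknown or untested is made for them only; others in the source may bear on it.

Working notes on the series. The three measured compounds share one core and differ only in the aryl group on a saturated chain carbon, two bonds along the chain from a carbonyl carbon: compound 1 `CC(C)C[C@H](N)c1cc(C(F)(F)F)ccc1N1CCN(C(=O)CCc2ccccc2Cl)CC1`, compound 2 `Cc1cccc(CCC(=O)N2CCN(c3ccc(C(F)(F)F)cc3[C@@H](N)CC(C)C)CC2)c1` and compound 3 `CC(C)C[C@H](N)c1cc(C(F)(F)F)ccc1N1CCN(C(=O)CCc2csc3ccccc23)CC1`. In an assay on HEK293 cells for displacement of a labelled ligand from Melanocortin receptor 4 (Homo sapiens) (on this read-out higher numbers stand for weaker inhibition and lower numbers for stronger inhibition), compound 1 gives 1700 nM, compound 2 gives 2100 nM and compound 3 gives 2300 nM. Compound 3 stands together with the other two rather than apart from them: the steps of a 1.4-fold higher number from compound 1 to compound 3 (0.13 log units; within the scatter) and a 1.1-fold higher number from compound 2 to compound 3 (0.04 log units; within the scatter) lie within the scatter, as does a 1.2-fold higher number from compound 1 to compound 2 (0.09 log units; within the scatter).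

Compound 4 `CC(C)C[C@H](N)c1cc(C(F)(F)F)ccc1N1CCN(C(=O)CCc2cn(C)c3ccccc23)CC1` is not yet measured. It differs from compound 3 by 1-methyl-1H-indol-3-yl in place of 1-benzothiophen-3-yl on a saturated chain carbon, two bonds along the chain from a carbonyl carbon. The three measured steps bear directly on this change, since each exchanges one aryl group for another at the same place, and none of them moved the number beyond the scatter. No step beyond the scatter is therefore expected here either, in neither direction; the expected step is no change at the digits printed from compound 3 to compound 4 (within the scatter). In this assay compound 4 is expected at about 2300 nM, with a range from 1100 nM to 5000 nM.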

Compound 4, inhibition constant: 3000 nM
For compound 4 the middle estimate is 1.3-fold (0.12 log units) below the measured one, within the range that was stated.
By their numbers in this assay, from the lowest: compounds 1, 2, 3 and 4 (each within the scatter of the next).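

In this assay, 1-methyl-1H-indol-3-yl behaves like the three earlier aryl groups at this saturated chain carbon, two bonds along the chain from a carbonyl carbon: the new steps (a 1.3-fold higher number from compound 3 to compound 4 (0.12 log units; within the scatter)), (a 1.4-fold higher number from compound 2 to compound 4 (0.15 log units; within the scatter)) and (a 1.8-fold higher number from compound 1 to compound 4 (0.25 log units; within the scatter)) all lie within the scatter. Going by these compounds alone, the series now spans a fourth aryl group, and exchanging the sulfur of 1-benzothiophen-3-yl for the methyl-bearing nitrogen of 1-methyl-1H-indol-3-yl produces no step that can be told from the scatter. No measurement offered here bears on why the values stay together.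

Still open, going by these compounds, is whether an amine or a carboxylic acid on the aryl group would move the number beyond the scatter. A longer chain between the carbonyl and the aryl group also remains untested in the compounds shown.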